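Swapping chloro for trifluoromethyl on the amide aryl ring

A few compounds are considered here, and "the series" means these few. Any claim that something is new, unique, unknown or untested is made for them only; others in the source may bear on it.

Compound 3 `COc1cc(-c2nn(-c3ccc(NC(=O)c4ccc(Cl)c(Cl)c4)cc3)cc2-c2ccncc2)ccc1Cl` carries a 3,4-dichlorophenyl group on its carbonyl carbon. In a functional assay on LOX IMVI cells (Homo sapiens) for antiproliferative activity, read by sulforhodamine B assay, with a stated time of 48 h (a lower number here means a stronger inhibitor, a higher number a weaker inhibitor), compound 3 gives 2760 nM, the highest of the three numbers recorded so far, though its gaps to both neighbours fall within the scatter. Compound 1 `COc1cc(-c2nn(-c3ccc(NC(=O)Nc4ccc(Cl)c(C(F)(F)F)c4)cc3)cc2-c2ccncc2)ccc1Cl`, the urea with a (4-chloro-3-(trifluoromethyl)phenyl)amino group, gives 1430 nM in this assay, and compound 2 `COc1cc(-c2nn(-c3ccc(NC(=O)Nc4cc(C(F)(F)F)cc(C(F)(F)F)c4)cc3)cc2-c2ccncc2)ccc1Cl` gives 1630 nM; these two values lie within the scatter of each other, so no order between them is claimed.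

Compound 4 `COc1cc(-c2nn(-c3ccc(NC(=O)c4ccc(Cl)c(C(F)(F)F)c4)cc3)cc2-c2ccncc2)ccc1Cl` differs from compound 3 by trifluoromethyl in place of chloro on an aromatic carbon. Within the data shown here, the only step measured that touches this aryl substituent is a 1.9-fold higher number from compound 1 to compound 3 (0.29 log units; within the scatter), which bundles the amide-for-urea exchange together with the change of substituent and still stays within the scatter. Among the measured compounds shown here, no measured pair isolates trifluoromethyl against chloro on an otherwise identical core, so the data give no ground to expect a step beyond the scatter in either direction. Compound 4 is therefore estimated at 2300 nM in this assay, with a range from 1100 nM to 5000 nM, which amounts to an expected step of a 1.2-fold lower number from compound 3 to compound 4 (0.08 log units; within the scatter).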

Compound 4, half-maximal inhibitory concentration: 1560 nM
For compound 4 the middle estimate is 1.5-fold (0.17 log units) above the measured one, within the range that was stated.
By their numbers in this assay, from the lowest: compounds 1, 4, 2 and 3 (each within the scatter of the next).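

In this assay, among these compounds, the pair of compound 3 and compound 4 isolates this position for the first time: trifluoromethyl in place of chloro on an aromatic carbon, ortho to a chloro group, gives a 1.8-fold lower number from compound 3 to compound 4 (0.25 log units; within the scatter) and so stays within the scatter, although the entering group counts 4 heavy atoms against 1 for the group that leaves. The second new step holds the 4-chloro-3-(trifluoromethyl)phenyl group constant and changes only what sits on the carbonyl carbon, giving a 1.1-fold higher number from compound 1 to compound 4 (0.04 log units; within the scatter) and so also staying within the scatter, which means the two changes bundled in the earlier step from compound 1 to compound 3 can now be read apart, and neither alone exceeds the scatter. No measurement is at hand that could explain either step.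

All steps among these four compounds lie within the scatter, so it remains open whether any replacement at this position can move the number beyond it. An amine or a carboxylic acid on this aromatic carbon, or a longer alkyl chain there, would test that on the same core.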